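This account rests on a few compounds, and the source may have more. Where it says the series, first, only, none or still open, it means among the compounds named here.

Compound 1 `CCCCCCCCCCCCOc1ccc(C(=O)/C=C/c2c(/C=C/c3ccc(OC)cc3)cc(OC)cc2OC)cc1`: 12.7 ug/mL
Compound 2 `COc1ccc(/C=C/c2cc(OC)cc(OC)c2/C=C/C(=O)c2ccc(C(F)(F)F)cc2)cc1`: 4.3 ug/mL

In a functional assay on B16-F10 cells (Mus musculus) for antiproliferative activity, read by MTT assay, with a stated time of 48 h (a lower number here means a stronger inhibitor, a higher number a weaker inhibitor), compound 2 gives the lower of the two numbers, and compound 1 stands clearly higher, beyond the usual scatter. Compound 3 `COc1ccc(/C=C/c2cc(OC)cc(OC)c2/C=C/C(=O)c2ccc(-c3ccccc3)cc2)cc1` has not yet been measured. It differs from compound 2 by phenyl in place of trifluoromethyl on an aromatic carbon. Going by the values given here, no pair of measured compounds shows the effect of such a change, and the one comparison available involves a different change at another place. The step of a 1.4-fold higher number from compound 2 to compound 3 (0.14 log units; within the scatter) is therefore expected to stay within the scatter, with no clear direction. In this assay compound 3 is estimated at 6 ug/mL, between 2 ug/mL and 18 ug/mL.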

Compound 3, half-maximal inhibitory concentration: 10.6 ug/mL
Compound 3: the middle estimate sits 1.8-fold (0.25 log units) below what was measured, and the stated range covers the measured number.
By their numbers in this assay, from the lowest: compound 2; then compounds 3 and 1 (each within the scatter of the next).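

In this assay, going by these compounds alone, phenyl in place of trifluoromethyl on this aromatic carbon, para to a large group, gives a 2.5-fold higher number from compound 2 to compound 3 (0.39 log units; beyond the scatter), the first single-place comparison at this position. It shows that this position responds to the group it carries, and that this exchange costs a modest loss of activity. No measurement offers an explanation for this step. Within the data shown here, with only two groups compared directly, no trend can be drawn, and it remains open whether a methyl, an amine or a carboxylic acid here would give a lower or higher number than trifluoromethyl.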